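The source may report more compounds than this note shows. Statements on the series, on what has been measured and on what is new or still open speak of the compounds shown alone.

Measured so far in a functional assay on MCF7 cells (Homo sapiens) for antiproliferative activity, read by MTT assay, with a stated time of 72 h; a lower number here means a stronger inhibitor, a higher number a weaker inhibitor:
compound 1 `C=C(C)C(=O)Nc1cc2c(N3CCc4ccccc43)ncnc2cc1OC` — 11100 nM
compound 2 `C=C(C)C(=O)Nc1cc2c(N3CCc4ccccc43)ncnc2cc1O[C@@H]1CCOC1` — 14700 nM
compound 3 `CCC/C=C/C(=O)Nc1cc2c(N3CCCc4ccccc43)ncnc2cc1OC` — 1210 nM

Among the measured compounds shown here, compound 2 gives the highest of the three numbers; compound 1 sits nearest, with a 1.3-fold higher number from compound 1 to compound 2 (0.12 log units; within the scatter), and compound 3 sits furthest, at a lower number beyond the scatter, though compound 3 differs from compound 2 in two places, so no single step connects them.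

Compound 4 `O=C(/C=C/CN1CCC(CO)CC1)Nc1cc2c(N3CCc4ccccc43)ncnc2cc1O[C@@H]1CCOC1` is not yet measured. Its difference from compound 2: 3-(4-(hydroxymethyl)piperidin-1-yl)prop-1-en-1-yl in place of 1-methylethenyl on a carbonyl carbon. For the measured compounds named here, no measured step touches this carbonyl carbon alone. Going by the values given here, what compound 3 shows is only that a longer alkenyl group on the carbonyl can go together with a lower number in this assay. On that slim ground a step toward a lower number is expected, uncertain in size, a 3.3-fold lower number from compound 2 to compound 4 (0.51 log units; beyond the scatter). Compound 4 is therefore estimated at 4500 nM, range 1200 nM to 16000 nM.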

Compound 4, half-maximal inhibitory concentration: 4690 nM
Beside the measured number, compound 4's estimate is 1.0-fold (0.02 log units) below it, and the stated range covers the measured number.
By their numbers in this assay, from the lowest: compound 3; then compound 4; then compounds 1 and 2 (each within the scatter of the next).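

In this assay the carbonyl carbon now has a step of its own: 3-(4-(hydroxymethyl)piperidin-1-yl)prop-1-en-1-yl in place of 1-methylethenyl gives a 3.1-fold lower number from compound 2 to compound 4 (0.50 log units; beyond the scatter) on the shared core. The position therefore accepts the larger group, with its six-membered non-aromatic ring, and the number still falls beyond the scatter. No measurement offered here accounts for this step.

Which part of the entering group goes with the step remains open. A dimethylamino group on the same chain, or a carboxylic acid in place of the hydroxymethyl, would bear on that.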